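This account rests on a few compounds, and the source may have more. Where it says the series, first, only, none or still open, it means among the compounds named here.

Working notes on the sulfamide series, toxicity part.

Three compounds have been run in an ADME assay on MT4 cells (Homo sapiens) for cytotoxicity, read by MTT assay, with a stated time of 5 days; on this read-out higher numbers stand for lower toxicity in this test and lower numbers for higher toxicity in this test. Compound 1 `O=C1N(Cc2ccc(Cl)cc2Cl)c2cccn2S(=O)(=O)N1Cc1ccccc1` gives 218000 nM. Compound 3 `N#CCN1C(=O)N(Cc2cccc(F)c2)S(=O)(=O)n2cccc21` gives 172000 nM; its number and that of compound 1 lie within the usual scatter of each other, so no order can be read between them. Compound 2 `N#Cc1ccccc1CN1C(=O)N(Cc2cccc(Cl)c2)S(=O)(=O)n2cccc21` reaches only the limit of this assay, > 293000 nM, and that value is a limit rather than a number; it is the point at which one of the three values sits (the limit of > 293000 nM in this assay, at which 1 of the 3 values shown sits). Compound 1 thus stands at the top of the two real numbers, with compound 3 close to it and compound 2 undetermined beyond the limit.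

Compound 4 `O=C1N(Cc2ccccc2)c2cccn2S(=O)(=O)N1Cc1ccccc1` has not been measured. It differs from compound 1 in one place: phenyl in place of 2,4-dichlorophenyl on a saturated chain carbon bound to an amide-type nitrogen in a ring. Among the compounds with values here, no measured pair in the set isolates this change, and all three measured compounds, whatever their benzyl substituents, sit near or beyond the upper end of this assay. The step from compound 1 to compound 4 is therefore expected to be small, of the order of the scatter, and if anything towards a higher number, a 1.1-fold higher number from compound 1 to compound 4 (0.06 log units; within the scatter). Compound 4 is estimated at 250000 nM, with a range from 120000 nM to 400000 nM, and a fair chance that only a limit is reported.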

Compound 4, half-maximal cytotoxic concentration: 196000 nM
For compound 4 the middle estimate is 1.3-fold (0.11 log units) above the measured one; low and high end bracket the measured number.
By their numbers in this assay, from the lowest: compounds 3, 4 and 1 (each within the scatter of the next). At a limit, above all of these: compound 2.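

In this assay, replacing 2,4-dichlorophenyl by phenyl on a saturated chain carbon bound to an amide-type nitrogen in a ring gives a 1.1-fold lower number from compound 1 to compound 4 (0.05 log units; within the scatter), so no order can be read between the two compounds. Within the data shown here, this is the first pair that isolates a single change, and it shows that, for this pair, taking away both chlorine atoms leaves the read-out unchanged within the scatter, with compound 4 still giving a number and not a limit. The data shown offer no explanation for this flat step, and none can be assigned to the chlorine atoms or to the size of the group.

Among these compounds, the series still has only this one pair, so it remains open whether an amine, a carboxylic acid or a longer chain in place of phenyl at this position would leave the read-out as flat as the two chlorine atoms do. Compound 2 has only a limit and not a number, and no step to it can be read: the limit of > 293000 nM in this assay, at which 1 of the 4 values shown sits.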